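This account rests on a few compounds, and the source may have more. Where it says the series, first, only, none or still open, it means among the compounds named here.

In a functional assay on A375P cells (Homo sapiens) for antiproliferative activity, read by MTT assay, with a stated time of 48 h (on this read-out higher numbers stand for weaker inhibition and lower numbers for stronger inhibition), the measured compounds stand as follows.
Compound 1 `COc1cc(-c2nn(-c3ccc(NC(=O)c4cc(Cl)cc(Cl)c4)cc3)cc2-c2ccncc2)ccc1Cl` gives > 20000 nM, which is a limit of this assay rather than a number (the limit of > 20000 nM in this assay, at which 1 of the 3 values shown sits).
Compound 2 `COc1cc(-c2nn(-c3ccc(NC(=O)c4ccc(Cl)c(C(F)(F)F)c4)cc3)cc2-c2ccncc2)ccc1Cl` gives 9800 nM.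
Compound 3 `O=C(Nc1ccc(-n2cc(-c3ccncc3)c(-c3ccc(Cl)c(O)c3)n2)cc1)c1cc(Cl)cc(Cl)c1` gives 6800 nM.

Compound 2 differs from compound 1 by 4-chloro-3-(trifluoromethyl)phenyl in place of 3,5-dichlorophenyl on a carbonyl carbon. That change gave an at least 2.0-fold lower number from compound 1 to compound 2 (0.30 log units; that floor lies within the scatter), and since compound 1 only sets a limit, the true step could be larger. Compound 3 differs from compound 1 in the core by hydrogen in place of methyl on an oxygen on an aromatic ring, which gave an at least 2.9-fold lower number from compound 1 to compound 3 (0.46 log units; beyond the scatter).

Compound 4 `O=C(Nc1ccc(-n2cc(-c3ccncc3)c(-c3ccc(Cl)c(O)c3)n2)cc1)c1ccc(Cl)c(C(F)(F)F)c1` has not yet been measured in this assay. It differs from compound 3 by 4-chloro-3-(trifluoromethyl)phenyl in place of 3,5-dichlorophenyl on a carbonyl carbon. For the measured compounds named here, this is the same change as from compound 1 to compound 2, on the same place in the shared core, so the step seen there is the only guide. The expected step is a 2.1-fold lower number from compound 3 to compound 4 (0.33 log units; beyond the scatter), set beside an at least 2.0-fold lower number from compound 1 to compound 2 (0.30 log units; that floor lies within the scatter), with the uncertainty that the earlier step rests on a limit. Compound 4 is therefore estimated at 3200 nM, expected to lie between 1200 nM and 8000 nM.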

Compound 4, half-maximal inhibitory concentration: 6800 nM
Compound 4: the middle estimate sits 2.1-fold (0.33 log units) below what was measured, and the stated range covers the measured number.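

In this assay, putting 4-chloro-3-(trifluoromethyl)phenyl in place of 3,5-dichlorophenyl on the carbonyl carbon gave no change at the digits printed from compound 3 to compound 4 (within the scatter), and the comparison with the earlier core reads: the same change on two cores in this assay, an at least 2.0-fold lower number (0.30 log units; that floor lies within the scatter) from compound 1 to compound 2 and no change at the digits printed (within the scatter) from compound 3 to compound 4; the limit leaves it open whether they differ. Putting hydrogen in place of methyl on the oxygen on the aromatic ring gave a 1.4-fold lower number from compound 2 to compound 4 (0.16 log units; within the scatter), and that comparison reads: the same change on two cores in this assay, an at least 2.9-fold lower number (0.46 log units; beyond the scatter) from compound 1 to compound 3 and a 1.4-fold lower number (0.16 log units; within the scatter) from compound 2 to compound 4; the limit leaves it open whether they differ. Neither new step goes beyond the scatter, but this does not show whether either change carries from one core to another: both earlier steps start from compound 1, whose > 20000 nM is a limit of the assay and not a number.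

The compounds shown leave open how a phenyl ring carrying an amine or a carboxylic acid would compare with these two chlorinated phenyl groups on the carbonyl carbon. They also leave open how an ethyl group or a longer chain on that oxygen would compare with methyl and hydrogen.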